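This account rests on a few compounds, and the source may have more. Where it says the series, first, only, none or still open, it means among the compounds named here.

Of the compounds shown here, three on a shared core have been measured in a physicochemical assay, with a stated time of 6 min; on this read-out lower numbers stand for stronger inhibition and higher numbers for weaker inhibition. Compound 1 `Cc1ccc(NC(=O)Nc2nc(-c3cc4cc(Br)ccc4o3)cs2)cc1` reads > 200000 nM, which is a limit of the assay and not a number. Compound 2 `O=C(Nc1ccc([N+](=O)[O-])cc1)Nc1nc(-c2cc3cc(Br)ccc3o2)cs1` reads > 200000 nM, again a limit and not a number. These two results form (the limit of > 200000 nM in this assay, at which 2 of the 3 values shown sit). Going by the values given here, compound 3 `O=C(Nc1nc(-c2cc3cc(Br)ccc3o2)cs1)Nc1ccccc1[N+](=O)[O-]` gives 166000 nM, the only true number among the three.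

The compound still to be measured is compound 4 `O=C(Nc1ccc(F)cc1)Nc1nc(-c2cc3cc(Br)ccc3o2)cs1`, which has 4-fluorophenyl in place of 2-nitrophenyl on an amide-type nitrogen. Two measured steps arrive at the 2-nitrophenyl group of compound 3: an at least 1.2-fold lower number from compound 1 to compound 3 (0.08 log units; that floor lies within the scatter) and an at least 1.2-fold lower number from compound 2 to compound 3 (0.08 log units; that floor lies within the scatter). Each gives only a floor, and that floor lies within the scatter. The remaining step, a step that the two limits leave unreadable from compound 1 to compound 2, has no readable size.

Compound 4 lacks the 2-nitrophenyl group, as do compound 1 and compound 2, so any movement is expected toward higher numbers. Given the small floor of an at least 1.2-fold lower number from compound 2 to compound 3 (0.08 log units; that floor lies within the scatter), no step beyond the scatter is expected in this assay. The expected step is a 1.2-fold higher number from compound 3 to compound 4 (0.08 log units; within the scatter). For compound 4 the estimated value is 200000 nM, with an expected range from 90000 nM to 400000 nM.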

Compound 4, half-maximal inhibitory concentration: > 200000 nM
Compound 4 gave a limit, no number; the forecaster's own chance of this, stated with the estimate: 60%; the middle value sits exactly at the limit.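

In this assay, 4-fluorophenyl in place of 2-nitrophenyl on the amide-type nitrogen gives an at least 1.2-fold higher number from compound 3 to compound 4 (0.08 log units; that floor lies within the scatter), so this change adds no difference that stands clear of the scatter. Compound 4 reads as a limit and not a number, which leaves its steps from compound 1 and from compound 2 unreadable. A fluoro group therefore joins methyl and nitro in a set of three phenyl groups that cannot be ranked against one another, with compound 3 the one compound that gives a number: the limit of > 200000 nM in this assay, at which 3 of the 4 values shown sit.

Going by these compounds, what remains open is whether any group on this nitrogen can bring the read-out clearly away from that limit, for instance a phenyl ring carrying an amine or a carboxylic acid, or a longer chain in place of the ring. Also open, on these data alone, is whether the number for compound 3 reflects anything more than a reading close to the limit.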